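Replacing Sulfamoyl with Oxazole on a Thiazole Core

This account rests on a few compounds, and the source may have more. Where it says the series, first, only, none or still open, it means among the compounds named here.

Of the compounds shown here, three have been measured in an assay on microsomes from liver (strain Wistar) for inhibition of acyl-CoA desaturase 1 (Rattus norvegicus), read by HPLC, with stated times of 1 h and 60 min; on this read-out lower numbers stand for stronger inhibition and higher numbers for weaker inhibition. Compound 1 `NC(=O)c1cnc(N2CCC(Sc3ccccc3C(F)(F)F)CC2)s1` gives 4 nM, compound 2 `NC(=O)c1nc(N2CCC(Oc3ccccc3C(F)(F)F)CC2)no1` gives 1630 nM, and compound 3 `NS(=O)(=O)c1cnc(N2CCC(Oc3ccccc3C(F)(F)F)CC2)s1` gives 41 nM. Compound 3 thus holds the second highest of the three numbers: compound 1 lies well below it, beyond the scatter, and compound 2 lies far above it, also beyond the scatter. Compound 4 `FC(F)(F)c1ccccc1OC1CCN(c2ncc(-c3ncco3)s2)CC1` keeps the ether-linked core of compound 3 and changes one thing: 1,3-oxazol-2-yl in place of sulfamoyl on an aromatic carbon. Going by the values given here, no measured pair shows this change, so its size is open. In this assay the change is expected to give a 2.0-fold higher number from compound 3 to compound 4 (0.29 log units; within the scatter), a modest shift toward weaker inhibition that may still fall within the scatter. Compound 4 is therefore estimated at 80 nM, with a range from 15 nM to 500 nM.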

Compound 4, half-maximal inhibitory concentration: 14 nM
Beside the measured number, compound 4's estimate is 5.7-fold (0.76 log units) above it, outside the stated range (below it).
By their numbers in this assay, from the lowest: compound 1; then compound 4; then compound 3; then compound 2.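

At the aromatic carbon next to the ring sulfur, sulfamoyl is not needed for strong inhibition: in this assay, putting 1,3-oxazol-2-yl there gives a 2.9-fold lower number from compound 3 to compound 4 (0.47 log units; beyond the scatter) and so a modest gain. In this pair, the change removes the hydrogen-bond donor of sulfamoyl and adds a five-membered aromatic ring without weakening inhibition. Nothing available explains this gain. On these data alone, it remains open how a pyridine ring, an amine or a carboxylic acid would fare at this carbon. As far as these compounds go, whether the gain comes from the oxazole ring specifically also remains unknown.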